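The source may report more compounds than this note shows. Statements on the series, on what has been measured and on what is new or still open speak of the compounds shown alone.

Measured compounds on a functional assay, read by fluorescence and spectrophotometry, with a stated time of 1 h; on this read-out higher numbers stand for an effect only at larger amounts of compound and lower numbers for an effect already at smaller amounts:
compound 1, `CCCCCCCCCCS(=O)(=O)/C=C/c1ccc(O)c(O)c1`, gives 6800 nM
compound 2, `O=S(=O)(/C=C/c1ccc(O)c(O)c1)CC1CCCO1`, gives 10500 nM
compound 3, `CCCCCCCCCCCS(=O)(=O)/C=C/c1ccc(O)c(O)c1`, gives 11400 nM

All three share the same catechol-bearing vinyl sulfone core and differ only in the group on the saturated chain carbon bound to the sulfonyl sulfur. Compound 2 falls between the other two numbers; its closest neighbour is compound 3 and its most distant is compound 1, and both gaps are within the usual scatter, so the three values are effectively indistinguishable on this assay.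

Only one measured step joins two of these compounds: a 1.7-fold higher number from compound 1 to compound 3 (0.22 log units; within the scatter). That change sits far from the sulfonyl sulfur and far from any ring, so it says little about what happens at the carbon next to the sulfonyl group.

Compound 4, `O=S(=O)(/C=C/c1ccc(O)c(O)c1)CC1CC1`, is not yet measured. It differs from compound 2 as follows: cyclopropyl in place of oxolan-2-yl on a saturated chain carbon bound to a sulfonyl sulfur. For the measured compounds named here, no measured pair swaps one ring for another at this place, so the expectation rests on the flatness of the series so far: the step of a 1.2-fold lower number from compound 2 to compound 4 (0.07 log units; within the scatter) is expected to stay within the scatter. The estimate for compound 4 on this assay is 9000 nM, with a range from 4000 nM to 20000 nM.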

Compound 4, half-maximal effective concentration: 10500 nM
Estimate against measurement, compound 4: 1.2-fold (0.07 log units) below; the range from low to high includes it.
By their numbers in this assay, from the lowest: compounds 1, 2, 4 and 3 (each within the scatter of the next).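

In this assay, for the compounds shown here, swapping oxolan-2-yl for cyclopropyl on a saturated chain carbon bound to a sulfonyl sulfur gives no change at the digits printed from compound 2 to compound 4 (within the scatter), the first direct reading of a ring-for-ring change at this place. The earlier step concerned only the far end of a saturated chain, whereas this pair compares two rings at the place itself. Oxolan-2-yl, a five-membered non-aromatic ring with 5 heavy atoms and 1 hydrogen-bond acceptor, and cyclopropyl, a three-membered non-aromatic ring of carbon only with 3 heavy atoms and 0 hydrogen-bond acceptors, read alike here, so neither the ring oxygen nor the difference in ring size registers on this read-out for this one pair. Nothing among the available data accounts for this equivalence.

Going by these compounds alone, it remains open whether an amine, a carboxylic acid or a phenyl ring at this place would also read alike, as the pair covers only two small non-aromatic rings. Also open, on these data alone, is whether the same swap would read alike on the same core with the two ring hydroxyl groups replaced by methoxy groups.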